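Morpholine Amide to Free Acid at the Same Core

The source may hold more compounds than are shown below. What is called first, only, known or untested is meant among the compounds shown, and "the series" means these compounds.

Compound 1, `O=C(O)/C=C/c1ccncc1-c1ccc2ccccc2c1`: 102% in an assay on a protein complex for inhibition of CDK8/Cyclin C (Homo sapiens), with a stated time of 1 h, tested at 10 uM; a higher number here means more inhibition at the concentration tested (going by the name of the read-out), a lower number less inhibition
Compound 2, `O=C(CCc1ccncc1-c1ccc2ccccc2c1)N1CCOCC1`: 100% in this assay

Compound 2 stands lowest of the two numbers, yet its nearest neighbour, compound 1, lies only within the scatter, so the two cannot be told apart; both numbers sit level with each other. Compound 3 `O=C(O)CCc1ccncc1-c1ccc2ccccc2c1` is not yet measured. It differs from compound 2 in a single place: hydroxy in place of morpholin-4-yl on a carbonyl carbon. Going by the values given here, no step between measured compounds is known, and with the number of compound 2 standing where it does, the expected step is a number 2 percentage points lower from compound 2 to compound 3 (within the scatter), nothing beyond the scatter. Compound 3 is therefore expected to give 98%, with a likely range from 85% to 105%.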

Compound 3, a percentage reported as inhibition, at one concentration (the size of the read-out at that concentration, not a potency): 101%
The estimate for compound 3 lay 3 percentage points below the measured number; measured number inside the range.
By their numbers in this assay, from the lowest: compounds 2, 3 and 1 (each within the scatter of the next).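

Hydroxy in place of morpholin-4-yl on a carbonyl carbon gives a number 1 percentage points higher from compound 2 to compound 3 (within the scatter) and 2-carboxyethyl in place of 2-carboxyethenyl on an aromatic carbon gives a number 1 percentage points lower from compound 1 to compound 3 (within the scatter) in this assay. At this single concentration, then, the carbonyl carbon carries either morpholin-4-yl or hydroxy with no readable difference, and the saturated and unsaturated chains cannot be told apart either. Nothing available here explains this level result. From the compounds shown here alone, whether an amine on the carbonyl carbon or a longer chain would stay this level remains open. So does whether these compounds would separate at a lower concentration.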